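The source may report more compounds than this note shows. Statements on the series, on what has been measured and on what is new or still open speak of the compounds shown alone.

Measured so far in a toxicity assay on NIH3T3 cells (Mus musculus) for cytotoxicity, read by resazurin assay; on this read-out lower numbers stand for an effect already at smaller amounts and higher numbers for an effect only at larger amounts of compound:
- compound 1 `c1ccc(-c2ccc(Cn3cncc3CNc3ccc(-c4ccccc4)c(-c4ccccc4)c3)cc2)cc1`: > 10000 nM
- compound 2 `O=C(OC1CCCCC1)c1ccc(NCc2cncn2Cc2ccc(-c3ccccc3)cc2)cc1-c1ccccc1`: > 10000 nM

Compound 2 stands at > 10000 nM, which is a limit and not a number. Compound 1 likewise gives only a limit. The whole measured series comes down to the limit of > 10000 nM in this assay, at which 2 of the 2 values shown sit.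

The next compound is compound 3 `c1ccc(-c2ccc(Cn3cncc3CNc3ccc(-c4cncs4)c(-c4ccccc4)c3)cc2)cc1`. The change is 1,3-thiazol-5-yl in place of cyclohexyloxycarbonyl on an aromatic carbon. In words, 1,3-thiazol-5-yl replaces cyclohexyloxycarbonyl on an aromatic carbon, ortho to a phenyl group.

Within the data shown here, the one measured step at this place is a step that the two limits leave unreadable from compound 1 to compound 2. On these data alone, it exchanged phenyl for cyclohexyloxycarbonyl, and its size remains unknown. Neither group gave a number in this assay, so the series offers no measured size to carry over to the new change. The expectation is therefore no step beyond the scatter in this assay, in either direction, with a report at the same limit the most likely outcome. The estimate means an expected step that the limit leaves unreadable from compound 2 to compound 3. For compound 3 the estimated value is 15000 nM, with an expected range from 6000 nM to 40000 nM.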

Compound 3, half-maximal effective concentration: > 1000 nM
Compound 3 was reported as a limit; the forecaster's own chance of this, stated with the estimate: 80%; the middle value lies beyond the limit too.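

In this assay compound 3 gives > 1000 nM, which is a limit and not a number. Among these compounds, with only limits for compound 1, compound 2 and compound 3, no step among them can be read. The compounds shown leave open at what concentration any of the three reaches a half-maximal effect in this assay, and whether phenyl, cyclohexyloxycarbonyl and 1,3-thiazol-5-yl differ there.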